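A sulfur-linked dichlorophenyl variant on a shared core

The compounds below may be only part of what the source reports. "The series", "measured", "known", "first", "only" and "open" are said of these compounds alone.

Of the compounds shown here, three built on the same core have been measured in a functional assay on DU-145 cells (Homo sapiens) for inhibition, read by sulforhodamine B assay, with a stated time of 48 h; a higher number here means a weaker inhibitor of growth, a lower number a stronger inhibitor of growth. Compound 1 `Nc1cc(N)c2nc(-c3ccccc3)c(NCc3ccc(Cl)c(Cl)c3)nc2c1` gives 16200 nM. Compound 3 `COc1cc(CNc2nc3cc(N)cc(N)c3nc2-c2ccccc2)cc(OC)c1OC` gives 5250 nM. For compound 2 `Nc1cc(N)c2nc(-c3ccccc3)c(Sc3ccc(F)cc3)nc2c1` the reading is only a limit of the assay, < 100000 nM, and not a number, as noted in the summary (the limit of < 100000 nM in this assay, at which 1 of the 3 values shown sits). Because only this limit is known, compound 2 cannot be placed among the other two values; the numbers for compound 1 and compound 3 lie apart from each other by more than the usual scatter.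

Compound 4 `Nc1cc(N)c2nc(-c3ccccc3)c(Sc3ccc(Cl)c(Cl)c3)nc2c1` has not yet been measured. It differs from compound 2 in one place: 3,4-dichlorophenyl in place of 4-fluorophenyl on a sulfur. Within the data shown here, no measured pair shows this change, so its effect is unknown. The step from compound 2 to compound 4 is expected to be a step that the limit leaves unreadable from compound 2 to compound 4, carrying compound 4 into the region where compound 1 and compound 3 sit. Compound 4 is estimated at 20000 nM, within a range from 4000 nM to 100000 nM.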

Compound 4, concentration for 50% growth inhibition: 1510 nM
Compound 4: middle estimate off by 13-fold (1.12 log units), on the high side; measured number below the stated range.
By their numbers in this assay, from the lowest: compound 4; then compound 3; then compound 1.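

The step from compound 2 to compound 4 cannot be read, because compound 2 has a limit and not a number in this assay: the limit of < 100000 nM in this assay, at which 1 of the 4 values shown sits. The compounds shown leave open how far 3,4-dichlorophenyl in place of 4-fluorophenyl on a sulfur moves growth inhibition.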